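A few compounds are considered here, and "the series" means these few. Any claim that something is new, unique, unknown or untested is made for them only; others in the source may bear on it.

Measured compounds:

- Compound 1 `O=[N+]([O-])c1cc(-c2nnn(CSc3nnnn3-c3ccc(Cl)cc3)n2)cc([N+](=O)[O-])c1`: 14000 nM
- Compound 2 `O=[N+]([O-])c1cc(-c2nnn(CSc3nnnn3-c3ccc(Br)cc3)n2)cc([N+](=O)[O-])c1`: 29000 nM

Both compounds were tested in an ADME assay on CHO-K1 cells (Cricetulus griseus) for cytotoxicity, read by MTT assay, with a stated time of 24 h; on this read-out lower numbers stand for stronger inhibition and higher numbers for weaker inhibition. Compound 1 gives 14000 nM in this assay, and compound 2 gives 29000 nM. The only difference between them is bromo in place of chloro on an aromatic carbon, and this shows up as a 2.1-fold higher number from compound 1 to compound 2 (0.32 log units; beyond the scatter). Among the two numbers, compound 2 therefore stands at the top, with compound 1 as its only neighbour.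

Compound 3 `O=[N+]([O-])c1cc(-c2nnn(CSc3nnnn3-c3ccc(Cl)c(Cl)c3)n2)cc([N+](=O)[O-])c1` has not yet been measured. Compared with compound 2 the change is 3,4-dichlorophenyl in place of 4-bromophenyl on an aromatic nitrogen. This change partly undoes the measured step, since chloro returns in place of bromo, and at the same time a second chloro enters on the same phenyl ring. The only step that bears on it is a 2.1-fold higher number from compound 1 to compound 2 (0.32 log units; beyond the scatter), a modest shift; reversing it points toward a somewhat lower number, while the second chloro has no measured precedent among these compounds. Because of a 2.1-fold higher number from compound 1 to compound 2 (0.32 log units; beyond the scatter), compound 3 is expected to land near compound 1, with a step of about a 1.9-fold lower number from compound 2 to compound 3 (0.29 log units; within the scatter). Compound 3 is thus estimated at 15000 nM, with a plausible range from 6000 nM to 45000 nM.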

Compound 3, half-maximal inhibitory concentration: 8700 nM
Compound 3: middle estimate off by 1.7-fold (0.24 log units), on the high side; low and high end bracket the measured number.
By their numbers in this assay, from the lowest: compounds 3 and 1 (each within the scatter of the next); then compound 2.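

In this assay, for the compounds shown here, the second chloro on the phenyl ring gives a 1.6-fold lower number from compound 1 to compound 3 (0.21 log units; within the scatter), a step that stays within the usual scatter, so this addition to the ring on the aromatic nitrogen cannot be told apart from the single chloro of compound 1. Going by these compounds alone, replacing 4-bromophenyl with 3,4-dichlorophenyl at the same place gives a 3.3-fold lower number from compound 2 to compound 3 (0.52 log units; beyond the scatter), which is beyond the scatter and sets compound 2 apart from both chloro compounds, with no compound among the three going against that split. No measurement here gives a reason for this split, and the numbers alone only describe it.

The compounds shown vary only the halogens on this one phenyl ring, which leaves open how the number would respond to a different kind of group there, such as an amine, a carboxylic acid or a methoxy group. They also leave open whether a 3,4-dibromophenyl group would read like compound 2 or like compound 3, and how changes elsewhere in the shared core would affect the number.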